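This account rests on a few compounds, and the source may have more. Where it says the series, first, only, none or still open, it means among the compounds named here.

Compound 1 `COc1ccc(C2CC(c3ccc(OC)c(OC)c3)=NN2)c(OC)c1` carries the shared core with a free ring nitrogen, and in a functional assay on the whole organism (strain albino) for inhibition, with Rattus norvegicus as the target, read by paw edema, with stated times of 30 min and 3 h, at a dose of 100 mg/kg by the oral route (a lower number here means less inhibition, a higher number more inhibition at the dose given (going by the name of the read-out)), compound 1 gives 42%. Compound 2 `COc1ccc(C2CC(c3ccc(OC)c(OC)c3)=NN2C(=O)CBr)c(OC)c1` is its acylated partner, and in this assay compound 2 gives 71%; the step of a number 29 percentage points higher from compound 1 to compound 2 (beyond the scatter) follows the (bromomethyl)carbonyl in place of hydrogen on an amine nitrogen in a ring. Compound 3 `COc1ccc(C2=NN(C(=O)C(C)Br)C(c3ccco3)C2)cc1OC` bears a (1-bromoethyl)carbonyl group and a furan-2-yl group, and in this assay compound 3 gives 42%. On the numbers shown, compound 3 stands level with compound 1 at the digits printed, the two together the lowest of the three, while compound 2 sits furthest from compound 3, higher by a difference beyond the scatter.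

Compound 4 `COc1ccc(C2CC(c3ccc(OC)c(OC)c3)=NN2C(=O)C(C)Br)c(OC)c1` differs from compound 3 by 2,4-dimethoxyphenyl in place of furan-2-yl on a saturated ring carbon. For the measured compounds named here, no measured pair shows this exchange of aryl groups directly; the one measured step, a number 29 percentage points higher from compound 1 to compound 2 (beyond the scatter), concerns the acyl group instead and only bears on the matter in that compound 4, like compound 2, combines a bromoacyl group with two dimethoxyphenyl-type rings on the core. Compound 4 is therefore expected to move upward from compound 3 by a number 18 percentage points higher from compound 3 to compound 4 (beyond the scatter), toward the level of compound 2, with some uncertainty because compound 3 gives 42% while carrying the same acyl group. The estimate for compound 4 in this assay is 60%, expected between 40% and 78%.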

Compound 4, a percentage reported as inhibition, in the whole organism at one dose (the size of the read-out at that dose, not a potency): 69%
Estimate against measurement, compound 4: 9 percentage points below, within the range that was stated.
By their numbers in this assay, from the lowest: compounds 1 and 3 (each within the scatter of the next); then compounds 4 and 2 (each within the scatter of the next).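

For the compounds shown here, with the (1-bromoethyl)carbonyl group held fixed in this assay, the exchange of furan-2-yl for 2,4-dimethoxyphenyl on the saturated ring carbon gives a number 27 percentage points higher from compound 3 to compound 4 (beyond the scatter) and so supplies the first direct reading of what the aryl group at this position does. On the side carrying 2,4-dimethoxyphenyl, placing the (1-bromoethyl)carbonyl group on the ring nitrogen gives a number 27 percentage points higher from compound 1 to compound 4 (beyond the scatter) in this series, which shows that a rise on acylation is not confined to the (bromomethyl)carbonyl group. The methyl on the chain carbon bound to bromine and the carbonyl carbon gives a number 2 percentage points lower from compound 2 to compound 4 (within the scatter) and so does not separate the two bromoacyl groups in this assay.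

On these data alone, what an amine in place of the bromine, or a plain phenyl on the saturated ring carbon, would give remains open, as does whether the aryl step holds with the (bromomethyl)carbonyl group. Nothing among the data shown offers an explanation for the aryl step, and the reason for it stays unknown.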